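A few compounds are considered here, and "the series" means these few. Any claim that something is new, unique, unknown or untested is made for them only; others in the source may bear on it.

Measured so far, in a functional assay on the whole organism with Mus musculus as the target; a higher number here means that more compound is needed for the effect, a lower number that less compound is needed:

Compound 1, `CCN(c1ccncc1)n1cccc1`: in this assay compound 1 gives > 20 mg/kg, which is a limit of the assay and not a number.
Compound 2, `CCCCN(c1ccncc1)n1cccc1`: in this assay compound 2 gives > 20 mg/kg, again only a limit.
Compound 3, `C=CCN(c1ccncc1)n1cccc1`: in this assay compound 3 gives > 20 mg/kg, also a limit.

Compound 1 therefore stands nowhere readable on the scale of this assay; only a limit is known for it, and the two further values shown are limits as well, all three sitting at the limit of > 20 mg/kg in this assay, at which 3 of the 3 values shown sit. The steps among them, a step that the two limits leave unreadable from compound 1 to compound 2, a step that the two limits leave unreadable from compound 1 to compound 3 and a step that the two limits leave unreadable from compound 2 to compound 3, cannot be given a size; all that is shown is that varying the chain on the nitrogen left the readout at the limit in every case.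

Compound 4, `CCN(c1ccncc1)n1cccc1Cl`, differs from compound 1 by chloro in place of hydrogen on an aromatic carbon. Within the data shown here, no measured step concerns this part of the core; the three steps above alter the chain, not the five-membered ring, so none of them bears on the change.

Given that every value shown sits at the limit of > 20 mg/kg in this assay, at which 3 of the 3 values shown sit, compound 4 is expected most likely to return a limit once more, with the step that the limit leaves unreadable from compound 1 to compound 4 then remaining unreadable. If a number does emerge in this assay, compound 4 is estimated at 30 mg/kg, within a range of 10 mg/kg to 100 mg/kg.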

Compound 4, dose for half-maximal effect: > 20 mg/kg
Compound 4 gave a limit, no number; the forecaster's own chance of this, stated with the estimate: 75%; the middle value lies beyond the limit too.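

Among these compounds, compound 4 and compound 1 both return only a limit in this assay, not a number, so chloro in place of hydrogen on the aromatic carbon gives no step of readable size. The compounds shown leave open how far any of them lies from the others, and all share one reading: the limit of > 20 mg/kg in this assay, at which 4 of the 4 values shown sit.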